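The source may hold more compounds than are shown below. What is called first, only, known or untested is meant among the compounds shown, and "the series" means these compounds.

Compound 1, `CC(C)[C@H](NC(=O)COc1cccc2ccccc12)C(=O)N[C@@H](CC(=O)O)C(=O)CSc1nnc(-c2ccccc2)o1`, gives 150000 nM in a functional assay on Jurkat cells (Homo sapiens) for inhibition; a lower number here means a stronger inhibitor, a higher number a weaker inhibitor.
Compound 2, `CC(C)[C@H](NC(=O)COc1cccc2ccccc12)C(=O)N[C@@H](CC(=O)O)C(=O)COc1nccc(C(F)(F)F)n1`, gives > 200000 nM in this assay.

Compound 2 sits at a limit of this assay rather than at a number, as the value of > 200000 nM shows; this is the limit of > 200000 nM in this assay, at which 1 of the 2 values shown sits. Among the measured compounds shown here, the only measured step, an at least 1.3-fold higher number from compound 1 to compound 2 (0.12 log units; that floor lies within the scatter), therefore has a floor that lies within the usual scatter, so it tells nothing more than that compound 2 is not a stronger inhibitor than compound 1, and both compounds are very weak inhibitors in this assay.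

Compound 3, `CC(C)[C@H](NC(=O)COc1cccc2ccccc12)C(=O)N[C@@H](CC(=O)O)C(=O)COc1ccc2ccccc2n1`, differs from compound 2 by quinolin-2-yl in place of 4-(trifluoromethyl)pyrimidin-2-yl on an oxygen on a saturated carbon. For the measured compounds named here, no measured step bears on this exchange directly; the one step measured, from a sulfanyl-linked oxadiazole to an oxygen-linked pyrimidine, did not move the number beyond the scatter and left compound 2 at the limit. Compound 3 is therefore expected to remain in the same very weak range, with a step of a number no higher from compound 2 to compound 3 (the limit leaves the size open) that is not expected to go beyond the scatter. The estimate for compound 3 in this assay is 200000 nM, between 60000 nM and 700000 nM, and it may well again be reported only as a limit.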

Compound 3, half-maximal inhibitory concentration: > 200000 nM
Compound 3: a limit, no number; the forecaster's own chance of this, stated with the estimate: 60%; the middle value sits exactly at the limit.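

In this assay compound 3 gives > 200000 nM, a limit and not a number, and it is the second compound to end there: the limit of > 200000 nM in this assay, at which 2 of the 3 values shown sit.

This shows that quinolin-2-yl on an oxygen on a saturated carbon, like 4-(trifluoromethyl)pyrimidin-2-yl at the same place, gives no readable inhibition in this range, even though the two groups differ in their rings and in the nitrogen and fluorine they carry. The step between compound 2 and compound 3 cannot be read, as both ends are limits. Among the compounds shown here, the change from the (5-phenyl-1,3,4-oxadiazol-2-yl)sulfanyl group to (quinolin-2-yl)oxy reads as an at least 1.3-fold higher number from compound 1 to compound 3 (0.12 log units; that floor lies within the scatter), so it shows only that compound 3 is not a stronger inhibitor than compound 1, the same result that compound 2 gave.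

On these data alone, how far compound 2 and compound 3 lie beyond the limit stays open, and so does any difference between them. Also open, as far as these compounds go, is whether a quinolin-2-yl group joined through sulfur instead of oxygen, or one carrying an amine, would bring a value inside the range of the assay.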